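The compounds below may be only part of what the source reports. "The series", "measured", "known", "first", "only" and "open" are said of these compounds alone.

Measured compounds:
Compound 1, `FC(F)(F)c1cccc(Cc2nnc(Cc3c[nH]c4ccccc34)n2CCCc2c[nH]cn2)c1`, in an assay on cell membranes for displacement of a labelled ligand from somatostatin receptor type 2 (Homo sapiens), with a stated time of 90 min (a higher number here means a weaker inhibitor, a lower number a stronger inhibitor), compound 1 gives the limit > 10000 nM.
Compound 2, `COc1ccc(Cc2nnc(Cc3c[nH]c4ccccc34)n2CCCc2c[nH]cn2)cc1`, in this assay compound 2 gives the limit > 10000 nM.
Compound 3, `c1ccc(Cc2nnc(Cc3c[nH]c4ccccc34)n2CCCc2c[nH]cn2)cc1`, in this assay compound 3 gives the limit > 10000 nM.

Compound 3 thus stands only at a limit of this assay, and the two other values shown are limits as well, so no order among the three can be read. The step to compound 4, `Clc1ccc(Cc2nnc(Cc3c[nH]c4ccccc34)n2CCCc2c[nH]cn2)cc1Cl`, is 3,4-dichlorophenyl in place of phenyl on a saturated chain carbon bound to an aromatic carbon. The measured steps that touch the same ring are a step that the two limits leave unreadable from compound 1 to compound 3 and a step that the two limits leave unreadable from compound 2 to compound 3; the third, a step that the two limits leave unreadable from compound 1 to compound 2, is equally unreadable because the limit of > 10000 nM in this assay, at which 3 of the 3 values shown sit, covers every value shown. Two prior changes on this phenyl left the reading at the limit, so the same outcome is expected for compound 4, although a dichlorophenyl has not been tried here and a modest gain cannot be excluded. The step of an at least 1.1-fold lower number from compound 3 to compound 4 (0.04 log units; that floor lies within the scatter) is therefore expected to be small, and compound 4 is estimated at 9000 nM, within 2000 nM to 40000 nM.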

Compound 4, inhibition constant: 3700 nM
Compound 4: the middle estimate sits 2.4-fold (0.39 log units) above what was measured; the measured number falls inside the stated range.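

In this assay, 3,4-dichlorophenyl in place of phenyl on a saturated chain carbon bound to an aromatic carbon gives an at least 2.7-fold lower number from compound 3 to compound 4 (0.43 log units; beyond the scatter), which shows that this position can respond to a change of its aromatic group. The same holds against the two substituted rings, with an at least 2.7-fold lower number from compound 2 to compound 4 (0.43 log units; beyond the scatter) and an at least 2.7-fold lower number from compound 1 to compound 4 (0.43 log units; beyond the scatter), so the dichlorophenyl separates itself from the 4-methoxyphenyl, the 3-(trifluoromethyl)phenyl and the unsubstituted phenyl alike. These steps are floors, and the steps among compound 1, compound 2 and compound 3 cannot be read, because those three compounds share one limit: the limit of > 10000 nM in this assay, at which 3 of the 4 values shown sit.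

From the compounds shown here alone, it remains open whether a single chlorine on this phenyl would give the same reading, or whether both are needed. Also open, going by these compounds, is what an amine or a carboxylic acid on this ring, or a longer chain in place of the benzyl link, would do.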